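Replacing the ester on the shared core: compound 4

A few compounds are considered here, and "the series" means these few. Any claim that something is new, unique, unknown or untested is made for them only; others in the source may bear on it.

Measured compounds in a functional assay on RAW264.7 cells (Mus musculus), read by fluorescence; a lower number here means a stronger inhibitor, a higher number a weaker inhibitor:
compound 1 `CCOC(=O)C1=CCCCC1S(=O)(=O)Cc1ccccc1` gives 101 nM
compound 2 `CCOC(=O)C1=CCCCC1S(=O)(=O)Cc1ccccc1F` gives 97 nM
compound 3 `COC(=O)C1=CCCCC1S(=O)(=O)Cc1ccc(F)cc1Cl` gives 99 nM

Compound 3 stands alongside compound 1 and compound 2 in this assay, all three within the scatter of one another. Compound 4 `CCC(O)C1=CCCCC1S(=O)(=O)Cc1ccc(F)cc1Cl` carries 1-hydroxypropyl in place of methoxycarbonyl on a double-bonded ring carbon. Going by the values given here, the only step between measured compounds, a 1.0-fold lower number from compound 1 to compound 2 (0.02 log units; within the scatter), concerns the aromatic ring, not the group on the double-bonded ring carbon, so no measured step informs this change. The three values give a tight starting point but no direction for it. A step of a 2.5-fold higher number from compound 3 to compound 4 (0.40 log units; beyond the scatter) is expected, with broad uncertainty on both sides. For compound 4 the estimate in this assay is 250 nM, range 50 nM to 1500 nM.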

Compound 4, half-maximal inhibitory concentration: > 10000 nM
Compound 4 was reported as a limit (the forecaster's own chance of this, stated with the estimate: 10%); middle value at least 40-fold (1.60 log units) away from the limit.
By their numbers in this assay, from the lowest: compounds 2, 3 and 1 (each within the scatter of the next). At a limit, above all of these: compound 4.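

In this assay 1-hydroxypropyl in place of methoxycarbonyl on the double-bonded ring carbon gives an at least 100-fold higher number from compound 3 to compound 4 (2.00 log units; beyond the scatter) and is the only change shown that moves the number beyond the scatter. Compounds 1, 2 and 3 all carry an ester there and sit within the scatter of one another, so they gave no sign that this position was sensitive. Compound 4 is reported only as a limit: the limit of > 10000 nM in this assay, at which 1 of the 4 values shown sits.

Going by these compounds, the change removes the ester and introduces the alcohol and the longer chain together, so which of these matters remains open. A carboxylic acid, an amide or a hydroxymethyl group on this carbon would help separate them.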